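The source may hold more compounds than are shown below. What is called first, only, known or untested is meant among the compounds shown, and "the series" means these compounds.

Measured compounds in a functional assay on HeLa cells (Homo sapiens) for cytotoxicity, read by WST assay, with a stated time of 48 h; a higher number here means a weaker inhibitor, a lower number a stronger inhibitor:

- compound 1, `Oc1cccc(/C=C/C[C@H]2C[C@@H]([C@@H](O)c3ccccc3)CO[C@@H]2c2ccccc2)c1`, compound 1 gives 18600 nM
- compound 2, `COc1cccc([C@H]2OC[C@H]([C@@H](O)c3ccc(OC)c(OC)c3)C[C@@H]2C/C=C/c2ccc(OC)c(OC)c2)c1`, compound 2 gives 21800 nM
- compound 3, `COc1cccc([C@@H]2OC[C@H]([C@@H](O)c3ccc(OC)c(OC)c3)C[C@H]2C/C=C/c2ccc(OC)c(OC)c2)c1`, compound 3 gives 30100 nM

Compound 1 has the lowest of the three numbers, but its gap to compound 2 and its gap to compound 3 both lie within the scatter, so the three measured compounds are not separated in this assay. Going by the values given here, the only step between measured compounds that differ in one place is a 1.4-fold higher number from compound 2 to compound 3 (0.14 log units; within the scatter), which rests on (the fact that compounds 2 and 3 differ only in the configuration as drawn); it does not touch the group on the double-bonded chain and gives no guide to a change there.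

Compound 4, `O[C@@H](c1ccccc1)[C@H]1CO[C@H](c2ccccc2)[C@@H](C/C=C/C2CCCC2)C1`, differs from compound 1 by cyclopentyl in place of 3-hydroxyphenyl on a double-bonded chain carbon bound to a double-bonded chain carbon. Among the compounds with values here, no measured step covers an exchange of this kind, so nothing points to a direction. With the three measured numbers sitting close together and no step beyond the scatter among them, the expectation for compound 4 is a number near compound 1 with a broad range, and the expected step of a 1.3-fold higher number from compound 1 to compound 4 (0.11 log units; within the scatter) is not expected to exceed the scatter in either direction. The estimate for compound 4 in this assay is therefore 24000 nM, with a range from 9000 nM to 65000 nM.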

Compound 4, half-maximal inhibitory concentration: 9330 nM
Compound 4: the middle estimate sits 2.6-fold (0.41 log units) above what was measured, and the stated range covers the measured number.
By their numbers in this assay, from the lowest: compounds 4, 1, 2 and 3 (each within the scatter of the next, the first and the last beyond it).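

In this assay, the exchange of 3-hydroxyphenyl for cyclopentyl on a double-bonded chain carbon bound to a double-bonded chain carbon gives a 2.0-fold lower number from compound 1 to compound 4 (0.30 log units; within the scatter), the first step read at this position. In this pair, 3-hydroxyphenyl, with one six-membered aromatic ring of carbon only and 1 hydrogen-bond donor, gives way to cyclopentyl, with one five-membered non-aromatic ring of carbon only and 0 hydrogen-bond donors, without a step beyond the scatter, so neither the aromatic ring nor the hydroxyl is needed for a number in this range. No available finding accounts for this step or bears on this exchange.

The single exchange removes the hydroxyl and the aromatic ring together, so the compounds shown do not separate the two; unsubstituted phenyl and cyclohexyl at this place would divide them. On these data alone, whether an amine, a carboxylic acid or a longer chain in place of cyclopentyl would give a step beyond the scatter in this assay also remains open.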